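This account rests on a few compounds, and the source may have more. Where it says the series, first, only, none or still open, it means among the compounds named here.

Measured compounds in this series:
compound 1 `C[C@](NC(=O)[C@H](CCCCN)NC(=O)[C@H](CCCNC(=N)N)NC(=O)c1ccccc1)(C(N)=O)c1ccccc1`
compound 2 `CC(NC(=O)[C@H](CCCCN)NC(=O)[C@H](CCCNC(=N)N)NC(=O)c1ccccc1)(C(N)=O)c1ccccc1`
compound 3 `CN(C(=O)c1ccccc1)[C@@H](CCCNC(=N)N)C(=O)N[C@@H](CCCCN)C(=O)N[C@@H](C(N)=O)c1ccccc1`

In an assay on isolated protein for inhibition of Trypsin (Homo sapiens), read by fluorescence, with a stated time of 15 min, tested at 50 uM (on this read-out lower numbers stand for less inhibition and higher numbers for more inhibition at the one concentration tested (going by the name of the read-out)), compound 1 gives 11.8%. For compound 2 the read-out in this assay is a limit, <= 5%. For compound 3 the read-out in this assay is likewise a limit, <= 5%. Compound 3 therefore stands at the floor of the numbers shown, alongside compound 2, and only compound 1 returns a number. For the measured compounds named here, the single step between measured compounds is a number at least 6.8 percentage points lower from compound 1 to compound 2 (that floor lies within the scatter); its size stays open because of the limit of <= 5% in this assay, at which 2 of the 3 values shown sit, and the pair differs only in drawing, as the fact that one of compounds 1 and 2 is drawn with a defined configuration and the other without, at the place where they differ records.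

Compound 4 `N=C(N)NCCC[C@H](NC(=O)C(=O)c1ccccc1)C(=O)N[C@@H](CCCCN)C(=O)N[C@@H](C(N)=O)c1ccccc1` differs from compound 3 by (benzoylcarbonyl)amino in place of benzoyl(methyl)amino on a saturated chain carbon bound to a carbonyl carbon and a saturated chain carbon. No measured step touches a group of this kind, so none gives a direction for this change, and the one step shown is within the scatter. Compound 4 is expected to stay near the floor, with an expected step of a number no lower from compound 3 to compound 4 (the limit leaves the size open), not beyond the scatter. Compound 4 is thus estimated at 5%, in the range 0% to 15%.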

Compound 4, a percentage reported as inhibition, at one concentration (the size of the read-out at that concentration, not a potency): 33.5%
Beside the measured number, compound 4's estimate is 28.5 percentage points below it; the whole stated range lies below it.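

In this assay, the change on a saturated chain carbon bound to a carbonyl carbon and a saturated chain carbon gives a number at least 28.5 percentage points higher from compound 3 to compound 4 (beyond the scatter), the only step shown that lies beyond the scatter. This place therefore responds to the group it carries: with (benzoylcarbonyl)amino in place of benzoyl(methyl)amino, the read-out of compound 4 rises clear of the floor where compound 3 stands. The value of compound 3 is a limit, so the step has a lower bound and its full size stays open: the limit of <= 5% in this assay, at which 2 of the 4 values shown sit.

The change removes the methyl group and adds a second carbonyl in one step, and the compounds shown do not separate these two parts. On these data alone, how a phenylacetyl group or a benzenesulfonyl group on the same nitrogen would read also stays open.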